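A few compounds are considered here, and "the series" means these few. Any claim that something is new, unique, unknown or untested is made for them only; others in the source may bear on it.

The two measured compounds share one core and differ only in the aryl group attached to it. Compound 1 `CCC1=C(O)c2c(oc(-c3ccc(C(C)C)cc3)cc2=O)C(CC)(CC)C1=O` gives 1.08 uM in a functional assay on KBVIN cells (Homo sapiens) for antiproliferative activity, read by sulforhodamine B assay, with a stated time of 3 days; a higher number here means that more compound is needed for the effect, a lower number that less compound is needed. Compound 2 `CCC1=C(O)c2c(oc(-c3ccc(C)c(Cl)c3)cc2=O)C(CC)(CC)C1=O` gives 2.15 uM in this assay. For the measured compounds named here, the single step between them, a 2.0-fold higher number from compound 1 to compound 2 (0.30 log units; within the scatter), is the only comparison available. Compound 2 thus stands at the higher of the two numbers, with compound 1 nearest and separated by a step that lies within the scatter, so no order between them can be claimed.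

Compound 3 `CCC1=C(O)c2c(oc(-c3cc(C)c(O)c(C)c3)cc2=O)C(CC)(CC)C1=O` has not yet been measured. It differs from compound 2 in one place: 4-hydroxy-3,5-dimethylphenyl in place of 3-chloro-4-methylphenyl on an aromatic carbon. Going by the values given here, the only measured step that bears on this kind of change is the one from compound 1 to compound 2, where one aryl group replaced another, and that step stayed within the scatter. There is no ground in these numbers to expect a step beyond the scatter in this assay in either direction.

Compound 3 is therefore expected to give about 2 uM in this assay, with a likely range from 0.8 uM to 5 uM. The expected step is a 1.1-fold lower number from compound 2 to compound 3 (0.03 log units; within the scatter), within the scatter.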

Compound 3, concentration for half-maximal effect: 8.9 uM
Estimate against measurement, compound 3: 4.5-fold (0.65 log units) below; measured number outside the range, above it.
By their numbers in this assay, from the lowest: compounds 1 and 2 (each within the scatter of the next); then compound 3.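

For the compounds shown here, the aryl group on this carbon next to the ring oxygen does matter after all: the first pair of compounds showed no readable difference, but this assay now gives a clear step when 4-hydroxy-3,5-dimethylphenyl enters (a 4.1-fold higher number from compound 2 to compound 3 (0.62 log units; beyond the scatter)), and a larger one against the 4-isopropylphenyl group (an 8.2-fold higher number from compound 1 to compound 3 (0.92 log units; beyond the scatter)). So this position does not treat every aryl group alike, and of the three groups shown, the one carrying a hydroxy group goes with the highest number, meaning that more compound is needed for the effect. Unlike 3-chloro-4-methylphenyl, with no hydrogen-bond donor or acceptor, the entering group has one of each, yet it also loses the chlorine and gains a methyl group, and no measurement here explains why the number moves.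

These compounds leave open which part of the change carries the step, since the hydroxy group and the two methyl groups arrive together and are never seen apart. They also leave open how the number would respond to a methoxy group or an amine on the same aryl ring.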